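This account rests on a few compounds, and the source may have more. Where it says the series, first, only, none or still open, it means among the compounds named here.

Measured in a functional assay on T47D cells (Homo sapiens) for inhibition, read by CCK-8 assay, with a stated time of 72 h, tested at 1 uM; a higher number here means more inhibition of growth at the concentration tested, a lower number less inhibition of growth:
- compound 1 `CN(C)C(=O)c1cc2cnc(Nc3ccc(NC(=O)C4(C(=O)Nc5ccc(F)cc5)CC4)cc3)nc2n1C1CCCC1`: 74.7%
- compound 2 `CN(C)C(=O)c1cc2cnc(Nc3ccc(NC(=O)C4(C(=O)Nc5ccccc5F)CC4)cc3)nc2n1C1CCCC1`: 85.2%
- compound 3 `CN(C)C(=O)c1cc2cnc(Nc3ccc(NC(=O)C4(C(=O)Nc5ccc(Br)cc5)CC4)cc3)nc2n1C1CCCC1`: 21.1%

Of the three, compound 3 stands lowest. The next structure, compound 4 `CN(C)C(=O)c1cc2cnc(Nc3ccc(NC(=O)C4(C(=O)Nc5cccc(C(F)(F)F)c5)CC4)cc3)nc2n1C1CCCC1`, has 3-(trifluoromethyl)phenyl in place of 4-bromophenyl on an amide-type nitrogen. The same site carries every measured change. Moving the fluoro group gave a number 10.5 percentage points higher from compound 1 to compound 2 (beyond the scatter), a modest step, whereas the two changes to 4-bromophenyl were large: a number 53.6 percentage points lower from compound 1 to compound 3 (beyond the scatter) and a number 64.1 percentage points lower from compound 2 to compound 3 (beyond the scatter). Among the compounds with values here, these steps show that the read-out can respond strongly to this aryl group, but no measured compound carries trifluoromethyl, so they do not fix the outcome. Within the data shown here, with compound 3 at 21.1%, the lowest value so far, a sizeable rise is expected, though with wide uncertainty. The expected change is a number 28.9 percentage points higher from compound 3 to compound 4 (beyond the scatter). The estimate for compound 4 is 50%, with an expected range from 20% to 82%.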

Compound 4, percent growth inhibition at one concentration: 9.7%
For compound 4 the middle estimate is 40.3 percentage points above the measured one, and the stated range ends above it.
By their numbers in this assay, from the lowest: compound 4; then compound 3; then compound 1; then compound 2.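

In this assay the loss at the amide-type nitrogen is no longer tied to 4-bromophenyl alone, since 3-(trifluoromethyl)phenyl also gives a number 75.5 percentage points lower from compound 2 to compound 4 (beyond the scatter) and a number 65 percentage points lower from compound 1 to compound 4 (beyond the scatter) in two large steps. The change from 4-bromophenyl adds only a number 11.4 percentage points lower from compound 3 to compound 4 (beyond the scatter) in a modest step, which leaves compound 4 the lowest of the four, beyond the scatter from each of the others. Among these four compounds, the two fluorophenyl amides stand high and the bromo and trifluoromethyl amides stand low.

No evidence is available to explain the sharp difference between these aryl groups. The compounds shown also leave open whether 3-fluorophenyl would stand with the fluorophenyl amides or with compound 4, and where 4-(trifluoromethyl)phenyl would fall.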